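A few compounds are considered here, and "the series" means these few. Any claim that something is new, unique, unknown or untested is made for them only; others in the source may bear on it.

Of the compounds shown here, two with a shared core have been measured in a physicochemical assay for lipophilicity; a higher number here means a more lipophilic compound, a lower number a more polar compound. Compound 1 (`C=C(C)COC[n+]1ccn(C)c1/C=N/O`) gives -1.83, and compound 2 (`C=C(C)CCOC[n+]1ccn(C)c1/C=N/O`) gives -1.41, the higher of the two numbers. Within the data shown here, the one measured step, a number 0.42 log units higher from compound 1 to compound 2 (beyond the scatter), is modest but beyond the scatter. It places 2-methylprop-2-en-1-yl where 1-methylethenyl stood, on a saturated chain carbon bound to an oxygen on a saturated carbon.

Compound 3 (`C=C(C)CC(OC[n+]1ccn(C)c1/C=N/O)C(=C)C`) has not yet been measured. Its difference is 1-methylethenyl in place of hydrogen on a saturated chain carbon bound to an oxygen on a saturated carbon and a saturated chain carbon: 1-methylethenyl in place of hydrogen, on a saturated chain carbon bound to an oxygen on a saturated carbon and a saturated chain carbon.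

Among the measured compounds shown here, no measured pair shows this exact change, so the single step above is only a loose guide. Both changes add carbon, and the measured one went upward in this assay, so a rise is expected here too, larger than that step but uncertain in size. The expected step is a number 0.86 log units higher from compound 2 to compound 3 (beyond the scatter). For compound 3 the estimated value is -0.55, with an expected range from -0.95 to -0.15.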

Compound 3, distribution coefficient: -0.62
Compound 3: the middle estimate sits 0.07 log units above what was measured; measured number inside the range.
By their numbers in this assay, from the lowest: compound 1; then compound 2; then compound 3.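

In this assay, the saturated chain carbon bound to an oxygen on a saturated carbon and a saturated chain carbon now has a measured change of its own: with 1-methylethenyl in place of hydrogen, the result is a number 0.79 log units higher from compound 2 to compound 3 (beyond the scatter) and the step is modest but beyond the scatter. Taken from the shorter compound, 2-methylprop-2-en-1-yl in place of hydrogen on a saturated chain carbon bound to a double-bonded chain carbon and an oxygen on a saturated carbon gives a number 1.21 log units higher from compound 1 to compound 3 (beyond the scatter) as a large step, so both single-place changes at this carbon point the same way as the earlier step, and no compound shown goes against that direction. No measurement among the data explains these rises.

The compounds shown leave open whether the number would still rise with an amine or a carboxylic acid at this carbon, since only groups made of carbon have entered so far. They also leave open whether a longer chain in place of 1-methylethenyl would carry the rise further or bring it to an end.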